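The source may hold more compounds than are shown below. What is called first, only, known or untested is meant among the compounds shown, and "the series" means these compounds.

Measured compounds:
compound 1 `CCCCCCCN1CCC(C(=O)Nc2cc(Cl)c(N)cc2OC)CC1`, in the whole-animal read-out > 10 mg/kg
compound 2 `COc1cc(N)c(Cl)cc1NC(=O)C1CCN(Cc2cccc(C#N)c2)CC1`, > 4 mg/kg
compound 3 `COc1cc(N)c(Cl)cc1NC(=O)C1CCN(CC2CCC2)CC1`, > 10 mg/kg

The read-out is a functional assay on the whole organism for antagonist activity, with Mus musculus as the target; on this read-out higher numbers stand for an effect only at larger amounts of compound and lower numbers for an effect already at smaller amounts. Compound 1 stands there only at a limit of the assay, > 10 mg/kg, and not at a number. Compound 2 likewise gives only a limit, > 4 mg/kg. Compound 3 too gives only a limit, > 10 mg/kg. With three limits and no number, the step that the two limits leave unreadable from compound 1 to compound 2 cannot be read, nor can a step that the two limits leave unreadable from compound 1 to compound 3 or a step that the two limits leave unreadable from compound 2 to compound 3; what can be said is the limit of > 10 mg/kg in this assay, at which 2 of the 3 values shown sit, and (the limit of > 4 mg/kg in this assay, at which 1 of the 3 values shown sits).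

Compound 4 `COc1cc(N)c(Cl)cc1NC(=O)C1CCN(CC2CCCC2)CC1` differs from compound 1 by cyclopentyl in place of hexyl on a saturated chain carbon bound to an amine nitrogen in a ring. The closest measured step is a step that the two limits leave unreadable from compound 1 to compound 3, in which a small carbon ring also replaces the hexyl chain, and that step is unreadable. Going by the values given here, no measured step gives a direction for the change in this assay, and nothing among the three measured compounds points to an effect within the dose range they covered. Compound 4 is therefore expected to behave like compound 1 in this assay, with the estimated step of a number no higher from compound 1 to compound 4 (the limit leaves the size open).

On that basis compound 4 is estimated at 10 mg/kg, with a range from 4 mg/kg to 30 mg/kg, and most likely the assay will again report only a limit.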

Compound 4, dose for half-maximal effect: > 10 mg/kg
Compound 4: only a limit was reported (the forecaster's own chance of this, stated with the estimate: 80%); the middle value lies on the limit itself.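

In this assay compound 4 gives only a limit, > 10 mg/kg. Going by these compounds alone, its steps to compound 1, compound 2 and compound 3 therefore cannot be read, and no new step follows from this result. The compounds shown leave open whether any group at this place gives a measurable effect, and how large any change there would be.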